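Swapping the phenyl for a substituted phenyl

The source may report more compounds than this note shows. Statements on the series, on what has been measured and on what is new or still open speak of the compounds shown alone.

Compound 2 `Cc1nn(-c2nc(-c3ccc(Cl)c(Cl)c3)c(SC(C)C)s2)c(C(=O)O)c1-c1ccccc1`: 3000 nM
Compound 1 `Cc1nn(-c2nc(-c3ccc(Cl)c(Cl)c3)c(SC(C)C)s2)c(C(=O)O)c1-c1cnccn1`: 14000 nM

In a functional assay on BJAB cells (Homo sapiens) for antiproliferative activity, with a stated time of 4 days (on this read-out higher numbers stand for an effect only at larger amounts of compound and lower numbers for an effect already at smaller amounts), compound 2 gives 3000 nM, the lowest of the two numbers; its nearest neighbour, compound 1, gives 14000 nM. Compound 3 `Cc1nn(-c2nc(-c3ccc(Cl)c(Cl)c3)c(SC(C)C)s2)c(C(=O)O)c1-c1cc(C#N)cc(C(F)(F)F)c1` has not been measured. It differs from compound 2 by 3-cyano-5-(trifluoromethyl)phenyl in place of phenyl on an aromatic carbon. Going by the values given here, the only measured step, a 4.7-fold lower number from compound 1 to compound 2 (0.67 log units; beyond the scatter), shows that exchanging the ring at this position changes the number modestly, but no step tests a substituted phenyl. A step of similar modest size in either direction is therefore expected, with a slightly lower number as the guess. Compound 3 is estimated at 1500 nM, range 300 nM to 8000 nM, a step of a 2.0-fold lower number from compound 2 to compound 3 (0.30 log units; within the scatter).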

Compound 3, half-maximal effective concentration: 3600 nM
Compound 3: middle estimate off by 2.4-fold (0.38 log units), on the low side, and the stated range covers the measured number.
By their numbers in this assay, from the lowest: compounds 2 and 3 (each within the scatter of the next); then compound 1.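

In this assay, the first substituted phenyl at this position shows a 1.2-fold higher number from compound 2 to compound 3 (0.08 log units; within the scatter) and so stays within the scatter of plain phenyl, even though 3-cyano-5-(trifluoromethyl)phenyl has 12 heavy atoms and phenyl has 6 heavy atoms. The same group also gives a 3.9-fold lower number from compound 1 to compound 3 (0.59 log units; beyond the scatter) when set against pyrazin-2-yl. Among these three compounds, then, both rings of carbon only stand apart from the ring of compound 1, and adding these two groups to the phenyl leaves the number in place.

On these data alone, whether a phenyl carrying only the nitrile or only the trifluoromethyl, or one carrying an amine or a methoxy group, would give a similar number remains open. Nothing measured here explains these numbers.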